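The source may report more compounds than this note shows. Statements on the series, on what has been measured and on what is new or still open speak of the compounds shown alone.

Compound 1 `Cn1ncnc1-c1cc(Oc2ccc(NC(=O)N/N=C/c3ccccc3)cc2F)ccn1`: > 100000 nM
Compound 2 `CN(C)CCn1cnnc1-c1cc(Oc2ccc(NC(=O)N/N=C/c3ccc(F)cc3F)cc2F)ccn1`: 1900 nM

In a functional assay on U-87MG ATCC cells (Homo sapiens) for cytotoxicity, read by MTT assay, with a stated time of 72 h (on this read-out higher numbers stand for weaker inhibition and lower numbers for stronger inhibition), compound 1 gives > 100000 nM, which is a limit of the assay rather than a number. Compound 1 stands at the limit of > 100000 nM in this assay, at which 1 of the 2 values shown sits. In this assay compound 2 gives 1900 nM, the only number shown here. Compound 3 `COc1cc(/C=N/NC(=O)Nc2ccc(Oc3ccnc(-c4nncn4CCN(C)C)c3)c(F)c2)ccc1O` differs from compound 2 in one place: 4-hydroxy-3-methoxyphenyl in place of 2,4-difluorophenyl on a carbon with a double bond to nitrogen. Among the compounds with values here, no step between measured compounds is available to set the size of this change, so a step of modest size in either direction in this assay is possible. Compound 3 is expected to give about 3500 nM in this assay, between 900 nM and 15000 nM. The estimated step from compound 2 to compound 3 is a 1.8-fold higher number from compound 2 to compound 3 (0.27 log units; within the scatter), a weakening expected to lie near the scatter.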

Compound 3, half-maximal inhibitory concentration: > 100000 nM
Compound 3: a limit, no number (the forecaster's own chance of this, stated with the estimate: 10%); at least 28-fold (1.45 log units) between middle value and limit.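

In this assay, the position on a carbon with a double bond to nitrogen proves sensitive to the aryl group it carries: 4-hydroxy-3-methoxyphenyl in place of 2,4-difluorophenyl gives an at least 52-fold higher number from compound 2 to compound 3 (1.72 log units; beyond the scatter). Within the data shown here, this is the first step that puts a size on a change at this position, and it lies well beyond the scatter. The value of compound 3 is a limit, not a number: the limit of > 100000 nM in this assay, at which 2 of the 3 values shown sit.

The compounds shown leave open whether the fluorines leaving or the hydroxyl and methoxy entering matter more. A phenyl carrying only a hydroxyl, or only a methoxy, would separate the two.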